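Swapping the amide ring amine on a cholesterol transporter series

The compounds below may be only part of what the source reports. "The series", "measured", "known", "first", "only" and "open" are said of these compounds alone.

Measured compounds:
- compound 1 `CC(C)(C)OC(=O)NCC1CCCN(C(=O)CN2CN(c3ccccc3)C3(CCN(C(=O)c4ccc(C5CCCCC5)cc4)CC3)C2=O)C1`: 3800 nM
- compound 2 `O=C(CN1CN(c2ccccc2)C2(CCN(C(=O)c3ccc(C4CCCCC4)cc3)CC2)C1=O)N1CCCCC1`: 1100 nM

In an assay on HEK293 cells for displacement of a labelled ligand from NPC1-like intracellular cholesterol transporter 1 (Homo sapiens) (a lower number here means a stronger inhibitor, a higher number a weaker inhibitor), compound 2 gives 1100 nM, the lower of the two numbers, with compound 1 the only comparator. The step of a 3.5-fold lower number from compound 1 to compound 2 (0.54 log units; beyond the scatter) shows that removing a substituent from the saturated ring of the amide helped. Compound 3 `CS(=O)(=O)N1CCN(C(=O)CN2CN(c3ccccc3)C3(CCN(C(=O)c4ccc(C5CCCCC5)cc4)CC3)C2=O)CC1` carries a different change: 4-(methylsulfonyl)piperazin-1-yl in place of piperidin-1-yl on a carbonyl carbon. Going by the values given here, no measured step tests this swap directly; the one step shows only that ring substitution on this amine cost potency. A small loss is therefore expected, a 1.8-fold higher number from compound 2 to compound 3 (0.26 log units; within the scatter), and compound 3 is estimated at 2000 nM (range 700 nM to 6000 nM).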

Compound 3, half-maximal inhibitory concentration: 6300 nM
Beside the measured number, compound 3's estimate is 3.2-fold (0.50 log units) below it, outside the stated range (above it).
By their numbers in this assay, from the lowest: compound 2; then compounds 1 and 3 (each within the scatter of the next).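

Replacing piperidin-1-yl with 4-(methylsulfonyl)piperazin-1-yl on this carbonyl carbon costs potency in this assay (a 5.7-fold higher number from compound 2 to compound 3 (0.76 log units; beyond the scatter)), so this position responds to a change of the ring itself, not only to a substituent on a saturated ring carbon. Compound 2, with the unsubstituted piperidin-1-yl, now holds the lowest number of the three. Nothing measured here accounts for this loss. The compounds shown leave open whether the loss goes with the methylsulfonyl group or with the piperazine ring itself, a question that a plain piperazin-1-yl or a morpholin-4-yl on the same carbonyl carbon would bear on.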